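The source may report more compounds than this note shows. Statements on the series, on what has been measured and on what is new or still open speak of the compounds shown alone.

Compound 1 `CC1=C(C(N)=O)C(c2ccoc2)NC(=O)N1`: 1%
Compound 2 `CC1=C(C(=O)NC(C)C)C(c2ccoc2)NC(=O)N1`: 1%
Compound 3 `CC1=C(C(=O)SC(C)C)C(c2ccoc2)NC(=O)N1`: 9%

All three share one core and differ only in the group on the carbonyl carbon. In an assay on membranes from CHO cells for displacement of a labelled ligand from adenosine receptor A1 (Homo sapiens), read by scintillation counting, with a stated time of 60 min, tested at 1 uM (a higher number here means more inhibition at the concentration tested (going by the name of the read-out), a lower number less inhibition), compound 1 gives 1% and compound 2 gives 1%, with no change at the digits printed from compound 1 to compound 2 (within the scatter). Compound 3 gives 9% in this assay; the steps of a number 8 percentage points higher from compound 1 to compound 3 (within the scatter) and a number 8 percentage points higher from compound 2 to compound 3 (within the scatter) are both within the scatter, so compound 3 sits together with the other two and none of the three can be set apart from the others.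

Compound 4 `CC1=C(C(=O)OCC2CCC2)C(c2ccoc2)NC(=O)N1` has not yet been measured. It differs from compound 3 by cyclobutylmethoxy in place of isopropylsulfanyl on a carbonyl carbon. For the measured compounds named here, the steps that bear on this change are those that also swapped the group on the carbonyl carbon: a number 8 percentage points higher from compound 1 to compound 3 (within the scatter) and a number 8 percentage points higher from compound 2 to compound 3 (within the scatter), both within the scatter. Going by the values given here, every change at this position so far has left the read-out in this assay essentially flat, so compound 4 is expected to stay in the same low region, with a step of a number 4 percentage points lower from compound 3 to compound 4 (within the scatter) that is not expected to go beyond the scatter. For compound 4 the estimate in this assay is 5%, with a range from 0% to 15%.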

Compound 4, a percentage reported as inhibition, at one concentration (the size of the read-out at that concentration, not a potency): 46%
The estimate for compound 4 lay 41 percentage points below the measured number; the whole stated range lies below it.
By their numbers in this assay, from the lowest: compounds 1, 2 and 3 (each within the scatter of the next); then compound 4.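

The group on the carbonyl carbon is not a silent position in this assay: cyclobutylmethoxy gives a number 37 percentage points higher from compound 3 to compound 4 (beyond the scatter), and measured against the other two groups it gives a number 45 percentage points higher from compound 2 to compound 4 (beyond the scatter) and a number 45 percentage points higher from compound 1 to compound 4 (beyond the scatter), whereas amino, isopropylamino and isopropylsulfanyl could not be told apart. The change from compound 3 to compound 4 alters several things at once: oxygen enters where sulfur leaves, the group gains heavy atoms, and a four-membered ring of carbon only appears, while the counts of hydrogen-bond donors and acceptors stay the same, so those counts do not separate the two compounds. Nothing available here shows which of these differences accounts for the step.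

The compounds shown leave open whether the oxygen or the cyclobutylmethyl part carries the step, which isopropoxy or cyclobutylmethylsulfanyl on the same carbonyl carbon would separate. Also open, from the compounds shown here alone, is whether the ring itself matters, as an open chain such as pentyloxy or a larger ring such as cyclohexylmethoxy in its place would show.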